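Replacing Acetyl with 2-Chlorobenzyl on the Ring Nitrogen

The compounds below may be only part of what the source reports. "The series", "measured", "known", "first", "only" and "open" are said of these compounds alone.

Of the compounds shown here, three built on one shared core have been measured in an assay on HEK293 cells for agonist activity at Toll-like receptor 8 (Homo sapiens), read by a luciferase reporter, with a stated time of 6 h; on this read-out higher numbers stand for an effect only at larger amounts of compound and lower numbers for an effect already at smaller amounts. Compound 1 `CCCCNc1nc(N)nc2c1CN(Cc1ccccc1)CC2` gives 0.06 uM. Compound 2 `CCCCNc1nc(N)nc2c1CN(C)CC2` gives 0.03 uM. Compound 3 `CCCCNc1nc(N)nc2c1CN(C(C)=O)CC2` gives 0.5 uM, the highest number of the three; the measured steps leading to it are an 8.3-fold higher number from compound 1 to compound 3 (0.92 log units; beyond the scatter) and a 17-fold higher number from compound 2 to compound 3 (1.22 log units; beyond the scatter). Compound 4 `CCCCNc1nc(N)nc2c1CN(Cc1ccccc1Cl)CC2` is not yet measured and differs from compound 3 in one place: 2-chlorobenzyl in place of acetyl on an amine nitrogen in a ring. The step that swapped benzyl for acetyl bears most on this change, and run backwards its modest size points to a lower number; the step from methyl points the same way. Compound 4 is therefore expected to give 0.06 uM, within 0.02 uM to 0.2 uM, an estimated 8.3-fold lower number from compound 3 to compound 4 (0.92 log units; beyond the scatter).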

Compound 4, minimum effective concentration: 0.05 uM
For compound 4 the middle estimate is 1.2-fold (0.08 log units) above the measured one; the range from low to high includes it.
By their numbers in this assay, from the lowest: compounds 2, 4 and 1 (each within the scatter of the next); then compound 3.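

Moving away from acetyl, 2-chlorobenzyl brings a 10-fold lower number from compound 3 to compound 4 (1.00 log units; beyond the scatter) and shows that this ring nitrogen can carry a substituted benzyl group without losing activity. Methyl and 2-chlorobenzyl cannot be told apart, with a 1.7-fold higher number from compound 2 to compound 4 (0.22 log units; within the scatter) as the gap between them, and the chloro group changes little, with a 1.2-fold lower number from compound 1 to compound 4 (0.08 log units; within the scatter) as its step, so among these compounds only acetyl stands apart. Nothing measured here explains why.

Still open, from the compounds shown here alone, is whether a benzyl ring carrying an amine or a carboxylic acid would give numbers as low as these. Going by these compounds, a longer carbon chain on the ring nitrogen is equally open.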